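Removing the Butyl Chain from a Toll-like Receptor 8 Agonist

This account rests on a few compounds, and the source may have more. Where it says the series, first, only, none or still open, it means among the compounds named here.

Measured compounds:
compound 1, `CCCCNc1oc2c(C)ncc(CO)c2c1Nc1ccccn1`: 9380 nM
compound 2, `CCCCCNc1oc2c(C)ncc(CO)c2c1Nc1cccc([N+](=O)[O-])c1`: 850 nM
compound 3, `CCCCCNc1oc2c(C)ncc(CO)c2c1Nc1cccc(F)c1`: 370 nM

The three compounds were tested in a functional assay on HEK293 cells for agonist activity at Toll-like receptor 8 (Homo sapiens), read by reporter gene assay; a higher number here means that more compound is needed for the effect, a lower number that less compound is needed. Compound 1 gives the highest number of the three; compound 2 sits nearest to it, and compound 3 furthest, with both gaps beyond the scatter. Compound 2 and compound 3 share the same core and pentylamino chain and differ only on the aromatic ring, where a 2.3-fold lower number from compound 2 to compound 3 (0.36 log units; beyond the scatter).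

Compound 4, `Cc1ncc(CO)c2c(Nc3ccccn3)c(N)oc12`, keeps the core and the pyridinyl group of compound 1 but carries hydrogen in place of butyl on a nitrogen on an aromatic ring. Within the data shown here, the only measured step, from compound 2 to compound 3, concerns a substituent on the other aromatic ring and says nothing about shortening or removing the alkyl chain on the nitrogen. The data therefore give no direct guide to the size or direction of this change.

Without a comparable step, the estimate rests on compound 1 alone, and the expected step for this change is estimated as a 2.1-fold higher number from compound 1 to compound 4 (0.33 log units; beyond the scatter), with a wide range leaning toward a higher number. The expected value for compound 4 in this assay is 20000 nM, with a range from 5000 nM to 80000 nM.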

Compound 4, half-maximal effective concentration: "not active" (no number reported)
The entry for compound 4 holds no number; there is nothing to compare the estimate with.
By their numbers in this assay, from the lowest: compound 3; then compound 2; then compound 1.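

Among these compounds, the entry for compound 4 reads "not active" and holds no number, so no step from compound 1 to compound 4 can be read. Nothing measured here explains this result. The compounds shown leave open how large the change from butylamino to amino really is on this scale.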